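The compounds below may be only part of what the source reports. "The series", "measured", "known", "first", "only" and "open" are said of these compounds alone.

Working notes on the series. The shared core of compound 1 `COc1cc2nc(N3CCN(c4ncccn4)CC3)nc(N)c2cc1OC` carries a ring amine substituted with pyrimidin-2-yl; in an assay on brain for binding affinity to Adrenergic receptor alpha-1 (Rattus norvegicus) (on this read-out lower numbers stand for stronger inhibition and higher numbers for weaker inhibition), compound 1 gives 0.26 nM. Compound 2 `COc1cc2nc(N3CCN(c4cnccn4)CC3)nc(N)c2cc1OC` has pyrazin-2-yl on that ring nitrogen and in this assay compound 2 gives 0.18 nM. Compound 3 `CCCOc1ccnc(N2CCN(c3nc(N)c4cc(OC)c(OC)cc4n3)CC2)n1` bears 4-propoxypyrimidin-2-yl there and in this assay compound 3 gives 0.32 nM. Compound 2 stands within the scatter of both neighbours: the move from compound 1 to compound 2 is a 1.4-fold lower number from compound 1 to compound 2 (0.16 log units; within the scatter), and the move from compound 2 to compound 3 is a 1.8-fold higher number from compound 2 to compound 3 (0.25 log units; within the scatter). Adding propoxy alone, from compound 1 to compound 3, gives a 1.2-fold higher number from compound 1 to compound 3 (0.09 log units; within the scatter).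

Compound 4 `COc1cc2nc(N3CCN(c4ccc(OC(C)C)nn4)CC3)nc(N)c2cc1OC` differs from compound 2 by 6-isopropoxypyridazin-3-yl in place of pyrazin-2-yl on an amine nitrogen in a ring. Going by the values given here, the steps that bear on this are a swap of ring heteroatoms in the six-membered aromatic ring and the addition of an alkoxy chain to it, both seen above; every one of them stayed within the scatter. Among the compounds with values here, no step in this assay beyond the scatter is therefore expected. The estimated step from compound 2 to compound 4 is a 1.7-fold higher number from compound 2 to compound 4 (0.22 log units; within the scatter). For compound 4 the expected value in this assay is 0.3 nM, with a range from 0.1 nM to 0.9 nM.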

Compound 4, inhibition constant: 0.29 nM
Beside the measured number, compound 4's estimate is 1.0-fold (0.01 log units) above it; the range from low to high includes it.
By their numbers in this assay, from the lowest: compounds 2, 1, 4 and 3 (each within the scatter of the next).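

With 6-isopropoxypyridazin-3-yl on the amine nitrogen in a ring, this assay still shows no step beyond the scatter: the three new steps are a 1.6-fold higher number from compound 2 to compound 4 (0.21 log units; within the scatter), a 1.1-fold higher number from compound 1 to compound 4 (0.05 log units; within the scatter) and a 1.1-fold lower number from compound 3 to compound 4 (0.04 log units; within the scatter). Among these four compounds, the position therefore holds its number within the scatter with an isopropoxy group on a pyridazin-3-yl ring, as it does with propoxy on a pyrimidin-2-yl ring, so the earlier result is not confined to a single ring type or to a straight chain. There is no measured information here to explain why the change of group leaves the number within the scatter.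

Compound 4 differs from the other compounds in both its aromatic ring and its alkoxy group, so the share of each in its steps cannot be read from these compounds. Also open, on these data alone, is whether an amine, a carboxylic acid or a longer chain on this aromatic ring would move the number beyond the scatter.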